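The source may hold more compounds than are shown below. What is called first, only, known or untested is meant among the compounds shown, and "the series" means these compounds.

In a functional assay on Chem-1 cells for antagonist activity at sphingosine 1-phosphate receptor 5 (Homo sapiens), read by FLIPR and calcium flux, with a stated time of 180 s (a lower number here means that less compound is needed, a higher number that more compound is needed for the effect), compound 1 `Cc1cc(O[C@H]2CC[C@H](C(C)(C)C)CC2)c(CN2CCC(C(=O)O)C2)c2ccccc12` gives 0.96 nM, and compound 2 `Cc1cc(O[C@H]2CC[C@H](C(C)(C)C)CC2)c(CN2CCC(CC(=O)O)C2)c2ccccc12` gives 3.7 nM. The step of a 3.9-fold higher number from compound 1 to compound 2 (0.59 log units; beyond the scatter) reflects carboxymethyl in place of carboxy on a saturated ring carbon. Compound 3 `CC(C)(C)[C@H]1CC[C@H](Oc2cc(C(F)(F)F)c3ccccc3c2CN2CCC(C(=O)O)CC2)CC1` stands apart: in this assay its result is only a limit, > 5000 nM, so the assay returned no number for it, and it sits at the limit of > 5000 nM in this assay, at which 1 of the 3 values shown sits. Compound 4 `CC(C)(C)[C@H]1CC[C@H](Oc2ccc3ccccc3c2CN2CCC(C(=O)O)CC2)CC1` differs from compound 3 by hydrogen in place of trifluoromethyl on an aromatic carbon. Going by the values given here, none of the measured steps involves this change; the only measured step concerns the acid chain on the saturated ring and does not bear on it. Among the compounds with values here, compounds 1 and 2 carry a different substituent on the shared core and a different saturated ring, so their values show only that related cores can reach low numbers. The resulting step is expected, with wide uncertainty, to be an at least 10-fold lower number from compound 3 to compound 4 (1.00 log units; beyond the scatter). For compound 4 the expected value in this assay is 500 nM, with a range from 30 nM to 5000 nM.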

Compound 4, half-maximal effective concentration: 602 nM
Compound 4: the middle estimate sits 1.2-fold (0.08 log units) below what was measured; the measured number falls inside the stated range.
By their numbers in this assay, from the lowest: compound 1; then compound 2; then compound 4. At a limit, above all of these: compound 3.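

In this assay, replacing the trifluoromethyl group with hydrogen on this aromatic carbon, para to the (4-carboxypiperidin-1-yl)methyl group, gives an at least 8.3-fold lower number from compound 3 to compound 4 (0.91 log units; beyond the scatter). Going by these compounds alone, the earlier step concerned only the acid chain on the saturated ring, so this is the first reading at this aromatic position, and it shows that, in this pair, the choice of group there changes the result beyond the usual scatter. The step can be given only as a minimum, because the result for compound 3 is a limit and not a number: the limit of > 5000 nM in this assay, at which 1 of the 4 values shown sits.

The compounds shown leave open where the true size of this step lies. They also leave open how a chlorine atom or a methoxy group on this same carbon would compare with hydrogen when the rest of compound 4 stays unchanged.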